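Swapping methoxy for hydroxy on compound 2

The source may hold more compounds than are shown below. What is called first, only, known or untested is meant among the compounds shown, and "the series" means these compounds.

Compound 1 `CCOC(=O)N1N=C(c2cccc(OC)c2)CC1c1cc(OC)c(OC)c(OC)c1` gives 9100 nM
Compound 2 `COc1cccc(C2=NN(C(=O)OCc3ccccc3)C(c3cc(OC)c(OC)c(OC)c3)C2)c1` gives > 10000 nM (a limit)

In a functional assay on MDA-MB-231 cells (Homo sapiens) for antiproliferative activity, read by MTT assay, with a stated time of 48 h (a lower number here means a stronger inhibitor of growth, a higher number a weaker inhibitor of growth), compound 2 gives > 10000 nM as a limit of the assay and not a number. Compound 3 `COc1cc(C2CC(c3cccc(O)c3)=NN2C(=O)OCc2ccccc2)cc(OC)c1OC` keeps the core of compound 2 and changes one group, with hydrogen in place of methyl on an oxygen on an aromatic ring as the difference, so that 3-methoxyphenyl becomes 3-hydroxyphenyl. Among the measured compounds shown here, the only measured step is an at least 1.0-fold higher number from compound 1 to compound 2 (0.04 log units; that floor lies within the scatter) and it lies within the scatter. For the measured compounds named here, that step also sits at another place on the molecule, so no measured pair tests methoxy to hydroxy. No step beyond the scatter is therefore expected in this assay for this change, although the uncertainty is wide and a limit is as likely as a number. an at least 1.1-fold lower number from compound 2 to compound 3 (0.04 log units; that floor lies within the scatter) is the expected step. Compound 3 is estimated at 9000 nM with a range from 3000 nM to 20000 nM as the expected span.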

Compound 3, concentration for 50% growth inhibition: > 10000 nM
Compound 3: only a limit was reported (the forecaster's own chance of this, stated with the estimate: 50%); middle value at least 1.1-fold (0.04 log units) from the limit.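

In this assay compound 2 gives > 10000 nM as a limit and not a number. Compound 3 gives > 10000 nM as a limit too. Among the compounds shown here, no step between compound 2 and compound 3 can be read, because both stop at the same point: the limit of > 10000 nM in this assay, at which 2 of the 3 values shown sit. The compounds shown leave open whether 3-hydroxyphenyl in place of 3-methoxyphenyl changes growth inhibition at all.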